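The compounds below may be only part of what the source reports. "The series", "measured", "known", "first", "only" and "open" are said of these compounds alone.

In a functional assay on HeLa cells (Homo sapiens) for antiproliferative activity, with a stated time of 24 h (a lower number here means a stronger inhibitor, a higher number a weaker inhibitor), the measured compounds stand as follows.
Compound 1 `NC(=O)c1c(NC(=O)c2ccccc2Cl)sc2c1CCN(C(=S)Nc1ccccc1Br)C2` gives 24600 nM.
Compound 2 `NC(=O)c1c(NC(=O)c2ccccc2I)sc2c1CCN(C(=S)Nc1ccccc1Cl)C2` reaches only the limit of the assay, > 50000 nM.
Compound 3 `NC(=O)c1c(NC(=O)c2ccccc2Br)sc2c1CCN(C(=S)Nc1ccccc1Br)C2` gives 24700 nM.

Compound 3 holds the highest of the two numbers; its nearest neighbour is compound 1, with a 1.0-fold higher number from compound 1 to compound 3 (0.00 log units; within the scatter). Compound 4 `NC(=O)c1c(NC(=O)c2ccccc2I)sc2c1CCN(C(=S)Nc1ccccc1Br)C2` carries iodo in place of bromo on an aromatic carbon. Going by the values given here, the only measured step at this position, a 1.0-fold higher number from compound 1 to compound 3 (0.00 log units; within the scatter), lies within the scatter. Among the compounds with values here, compound 2, the one measured compound with iodo on that ring, sits at the limit of > 50000 nM in this assay, at which 1 of the 3 values shown sits, though it also differs elsewhere. No step beyond the scatter is therefore expected in this assay, and the estimate is a 1.3-fold higher number from compound 3 to compound 4 (0.11 log units; within the scatter). Compound 4 is expected near 32000 nM, between 14000 nM and 75000 nM, with a fair chance of only a limit.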

Compound 4, half-maximal inhibitory concentration: > 50000 nM
Compound 4: no number, only a limit; the forecaster's own chance of this, stated with the estimate: 40%; middle value at least 1.5-fold (0.19 log units) from the limit.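

In this assay, chloro and bromo at this place gave a 1.0-fold higher number from compound 1 to compound 3 (0.00 log units; within the scatter), whereas iodo can now be read with nothing else altered: an at least 2.0-fold higher number from compound 3 to compound 4 (0.30 log units; that floor lies within the scatter), and an at least 2.0-fold higher number from compound 1 to compound 4 (0.30 log units; that floor lies within the scatter). From the compounds shown here alone, both floors lie within the scatter, so the result shows only that iodo brings no lower number here, and the true size of the change stays unknown. The step from compound 2 to compound 4 cannot be read, and the limit is now shared: the limit of > 50000 nM in this assay, at which 2 of the 4 values shown sit.

Going by these compounds, whether compound 4 lies just past that limit or far beyond it remains open. On these data alone, how a methoxy group or an amine would read at this place also stays open.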